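The source may report more compounds than this note shows. Statements on the series, on what has been measured and on what is new or still open speak of the compounds shown alone.

In an in vivo ADME assay on the whole organism (Cavia porcellus) (on this read-out lower numbers stand for a shorter-lived compound and higher numbers for a longer-lived compound), compound 1 `CC(NC(=O)c1ccc(C(=N)N)cc1)C(C)(C)C(=O)N1CCC(CC(=O)O)CC1` gives 0.883 h and compound 2 `CCC(NC(=O)c1ccc(C(=N)N)cc1)C(C)(C)C(=O)N1CCC(CC(=O)O)CC1` gives 1.3 h, so compound 2 stands within the scatter of compound 1. Compound 3 `CCCC(NC(=O)c1ccc(C(=N)N)cc1)C(C)(C)C(=O)N1CCC(CC(=O)O)CC1` differs from compound 2 by methyl in place of hydrogen on a saturated chain carbon, three bonds along the chain from an amide-type nitrogen. For the measured compounds named here, only one measured step bears on this, the same replacement two bonds along the chain: a 1.5-fold higher number from compound 1 to compound 2 (0.17 log units; within the scatter). With a single step as precedent, no change beyond the scatter is expected in this assay. The expected step is a 1.2-fold higher number from compound 2 to compound 3 (0.06 log units; within the scatter). Compound 3 is estimated at 1.5 h, with an expected range of 0.8 h to 2.8 h.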

Compound 3, half-life: 0.9 h
For compound 3 the middle estimate is 1.7-fold (0.22 log units) above the measured one, within the range that was stated.
By their numbers in this assay, from the lowest: compounds 1, 3 and 2 (each within the scatter of the next).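

Ethyl to propyl at this position gives a 1.4-fold lower number from compound 2 to compound 3 (0.16 log units; within the scatter) in this assay and the longer replacement of hydrogen, taken from the methyl of the shared core, gives a 1.0-fold higher number from compound 1 to compound 3 (0.01 log units; within the scatter) within the same read-out. Through methyl, ethyl and propyl, chain length therefore shows no effect beyond the scatter, and compound 3 adds no trend to the single earlier step. Nothing available offers an explanation for these numbers.

On these data alone, whether a longer chain, or an amine or carboxylic acid at the end of this chain, would move the half-life beyond the scatter remains open.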